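The compounds below may be only part of what the source reports. "The series", "measured", "known", "first", "only" and "open" are said of these compounds alone.

Working notes on the series. Of the compounds shown here, three with a shared core have been measured in an assay on microsomes from liver for inhibition of 3-hydroxy-3-methylglutaryl-coenzyme A reductase (Rattus norvegicus); a higher number here means a weaker inhibitor, a lower number a stronger inhibitor. Compound 1 `CC(C)c1c(C(=O)NCc2ccccc2)nn(-c2ccc(F)cc2)c1OC[C@@H](O)C[C@@H](O)CC(=O)O` gives 3.8 nM. Compound 2 `CC(C)c1c(C(=O)N2CCC[C@H](c3ccccc3)C2)nn(-c2ccc(F)cc2)c1OC[C@@H](O)C[C@@H](O)CC(=O)O` gives 4.8 nM. Compound 3 `COc1cccc(CNC(=O)c2nn(-c3ccc(F)cc3)c(OC[C@@H](O)C[C@@H](O)CC(=O)O)c2C(C)C)c1` gives 16 nM, the highest of the three numbers, both other steps to it lying beyond the scatter. Compound 4 `CC(C)c1c(C(=O)NCc2ccc(Cl)cc2)nn(-c2ccc(F)cc2)c1OC[C@@H](O)C[C@@H](O)CC(=O)O` is not yet measured; it differs from compound 3 by 4-chlorophenyl in place of 3-methoxyphenyl on a saturated chain carbon bound to an amide-type nitrogen. The measured step that bears on this is a 4.2-fold higher number from compound 1 to compound 3 (0.62 log units; beyond the scatter), a modest rise; taking the methoxy away again should undo part of that. Among the compounds with values here, no measured step covers a chlorophenyl, so that part of the change is open. A modest move toward a lower number is expected, a 2.7-fold lower number from compound 3 to compound 4 (0.43 log units; beyond the scatter). Compound 4 is estimated at 6 nM, with a range of 2.5 nM to 15 nM.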

Compound 4, half-maximal inhibitory concentration: 6.7 nM
Compound 4: the middle estimate sits 1.1-fold (0.05 log units) below what was measured, and the stated range covers the measured number.
By their numbers in this assay, from the lowest: compounds 1, 2 and 4 (each within the scatter of the next); then compound 3.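

Chloro in place of hydrogen on the aromatic carbon of the benzyl group gives a 1.8-fold higher number from compound 1 to compound 4 (0.25 log units; within the scatter), so a substituent on this ring does not always carry the loss seen with compound 3. The change from 3-methoxyphenyl to 4-chlorophenyl gives a 2.4-fold lower number from compound 3 to compound 4 (0.38 log units; beyond the scatter), and the (4-chlorobenzyl)amino group stands level with the 3-phenylpiperidin-1-yl group, at a 1.4-fold higher number from compound 2 to compound 4 (0.14 log units; within the scatter). No evidence at hand accounts for the gap between the two substituents.

The substituent and its ring position changed together in this step, so their contributions remain unseparated. A 3-chlorobenzyl or 4-methoxybenzyl amide would tell them apart.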